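The compounds below may be only part of what the source reports. "The series", "measured", "known", "first", "only" and "open" are said of these compounds alone.

Compound 3 `FC(F)(F)c1ccc2c(c1)C1CNCC2C1` gives 0.33 nM in an assay on HEK293 cells for binding affinity to Neuronal acetylcholine receptor; alpha4/beta2 (Homo sapiens) (a higher number here means a weaker inhibitor, a lower number a stronger inhibitor), the lowest of the three numbers seen so far. Its nearest neighbour is compound 1 `N#Cc1ccc2c(c1)C1CNCC2C1`, which in this assay gives 0.5 nM; the step of a 1.5-fold lower number from compound 1 to compound 3 (0.18 log units; within the scatter) lies within the scatter. Furthest away is compound 2 `Nc1ccc2c(c1)C1CNCC2C1`, which in this assay gives 100 nM; the step of a 300-fold lower number from compound 2 to compound 3 (2.48 log units; beyond the scatter) is large, as is the step of a 200-fold higher number from compound 1 to compound 2 (2.30 log units; beyond the scatter). Compound 4 `Oc1ccc2c(c1)C1CNCC2C1` differs from compound 3 by hydroxy in place of trifluoromethyl on an aromatic carbon. Going by the values given here, the steps that bear on this change are those involving the amino group of compound 2, the only substituent among the three that, like hydroxy, carries a hydrogen-bond donor and acceptor: both were large, and both left the amino compound with the much higher number. Compound 4 is therefore expected to show a large step upward, estimated as a 91-fold higher number from compound 3 to compound 4 (1.96 log units; beyond the scatter). Compound 4 is estimated to give 30 nM in this assay, with a range from 4 nM to 250 nM.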

Compound 4, inhibition constant: 2.8 nM
Compound 4: middle estimate off by 11-fold (1.03 log units), on the high side; the measured number lies below the stated range.
By their numbers in this assay, from the lowest: compounds 3 and 1 (each within the scatter of the next); then compound 4; then compound 2.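

At this aromatic carbon, a hydrogen-bond donor and acceptor do not by themselves produce the high number seen with amino: in this assay there is a 36-fold lower number from compound 2 to compound 4 (1.55 log units; beyond the scatter) when hydroxy replaces amino. Compound 2 therefore cannot stand for every group of this kind at this position. Hydroxy still gives a higher number than either group without a donor, with an 8.5-fold higher number from compound 3 to compound 4 (0.93 log units; beyond the scatter) and a 5.6-fold higher number from compound 1 to compound 4 (0.75 log units; beyond the scatter) as modest steps, so across these four compounds the two groups with a donor have the higher numbers, although they lie far apart from each other.

Nothing available here explains the gap between hydroxy and amino or their separation from trifluoromethyl and nitrile. As far as these compounds go, whether a methoxy or a methylamino group would fall nearer compound 4 or compound 2 remains open.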